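Aryl swap on the shared core: naphthalen-2-yl to 4-chlorophenyl

The source may hold more compounds than are shown below. What is called first, only, known or untested is meant among the compounds shown, and "the series" means these compounds.

In a functional assay on SK-N-SH cells (Homo sapiens) for cytotoxicity, read by MTT assay, with a stated time of 48 h (on this read-out higher numbers stand for weaker inhibition and lower numbers for stronger inhibition), compound 1 (`COc1ccc(/C=C/c2cc(OC)c(OC)c(OC)c2-c2ccc(F)c(F)c2)cc1`) gives 6900 nM and compound 2 (`COc1ccc(/C=C/c2cc(OC)c(OC)c(OC)c2-c2ccc3ccccc3c2)cc1`) gives 16000 nM on the shared core, so compound 2 holds the higher of the two numbers and the weaker inhibition of the pair.

The next structure, compound 3 (`COc1ccc(/C=C/c2cc(OC)c(OC)c(OC)c2-c2ccc(Cl)cc2)cc1`), differs from compound 2 as follows: 4-chlorophenyl in place of naphthalen-2-yl on an aromatic carbon with 4-chlorophenyl in place of naphthalen-2-yl on an aromatic carbon, ortho to a 2-(4-methoxyphenyl)ethenyl group.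

Among the compounds with values here, only one measured step bears on this change: a 2.3-fold higher number from compound 1 to compound 2 (0.37 log units; beyond the scatter) for naphthalen-2-yl in place of 3,4-difluorophenyl, modest but beyond the scatter. Compound 3 returns to a substituted phenyl group, as in compound 1, so that step read backwards is the nearest guide. A lower number of similar modest size is therefore expected in this assay, although a single step on a differently substituted group is thin support.

The expected change is a 2.1-fold lower number from compound 2 to compound 3 (0.33 log units; beyond the scatter) and remains an estimate. Compound 3 is estimated at 7500 nM with an expected range from 3000 nM to 17000 nM in this series.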

Compound 3, half-maximal inhibitory concentration: 15000 nM
The estimate for compound 3 lay 2.0-fold (0.30 log units) below the measured number; low and high end bracket the measured number.
By their numbers in this assay, from the lowest: compound 1; then compounds 3 and 2 (each within the scatter of the next).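

In this assay, 4-chlorophenyl in place of naphthalen-2-yl gives a 1.1-fold lower number from compound 2 to compound 3 (0.03 log units; within the scatter) and so, at this carbon ortho to a 2-(4-methoxyphenyl)ethenyl group, these two groups cannot be told apart, even though one six-membered aromatic ring leaves the structure and a chlorine enters. The two substituted phenyl groups do not read alike: 4-chlorophenyl in place of 3,4-difluorophenyl gives a 2.2-fold higher number from compound 1 to compound 3 (0.34 log units; beyond the scatter) as its step, so having a single substituted phenyl group here does not by itself match compound 1, which holds the lowest number of the three and the strongest inhibition. No measured information on the groups accompanies these numbers, and the steps stay unexplained.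

3,4-Difluorophenyl and 4-chlorophenyl differ in both halogen and substitution pattern, so it remains open which of the two separates compound 1 from compound 3; unsubstituted phenyl, 4-fluorophenyl and 3,4-dichlorophenyl at this carbon would divide those two differences. Also open, as far as these compounds go, is how the number responds when this aryl group carries an amine or a carboxylic acid in place of halogen.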